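A tetracyclic core: switching an azetidine for an arylamine

The source may hold more compounds than are shown below. What is called first, only, known or untested is meant among the compounds shown, and "the series" means these compounds.

The three measured compounds share one core, differing only in the group on a double-bonded ring carbon. Compound 1 `O=C1C(Nc2ccc(I)cc2)=CC(=O)c2c1nc1n2[C@H]2OC[C@@H](O)[C@H]2OC1` carries a 4-iodophenylamino group there and in a functional assay on MGC-803 cells (Homo sapiens) for inhibition, read by sulforhodamine B assay (on this read-out lower numbers stand for stronger inhibition and higher numbers for weaker inhibition), compound 1 gives 2150 nM. Compound 3 `O=C1C(NC2CC2)=CC(=O)c2c1nc1n2[C@H]2OC[C@@H](O)[C@H]2OC1` carries a cyclopropylamino group instead; in this assay compound 3 reaches only a limit, > 4000 nM. Going by the values given here, the single step between measured neighbours, an at least 1.8-fold higher number from compound 1 to compound 3 (0.26 log units; that floor lies within the scatter), is therefore bounded by the limit of > 4000 nM in this assay, at which 1 of the 3 values shown sits. Compound 2 `O=C1C=C(N2CCC2)C(=O)c2c1nc1n2[C@H]2OC[C@@H](O)[C@H]2OC1` carries an azetidin-1-yl group and likewise gives only a limit in this assay, > 16000 nM, as stated by the limit of > 16000 nM in this assay, at which 1 of the 3 values shown sits, so its number is not known.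

Compound 4 `COc1cccc(NC2=CC(=O)c3nc4n(c3C2=O)[C@H]2OC[C@@H](O)[C@H]2OC4)c1` is the next step from compound 2: (3-methoxyphenyl)amino in place of azetidin-1-yl on a double-bonded ring carbon. Among the compounds with values here, no measured step matches this change exactly; the closest comparison is that compound 1, whose group is also an arylamine, stands below both limits, while the smaller ring amines of compounds 2 and 3 give no number at all. On that basis compound 4 is expected to move toward compound 1, a step of about an at least 5.3-fold lower number from compound 2 to compound 4 (0.72 log units; beyond the scatter) toward stronger inhibition. My estimate for compound 4 is 3000 nM, with a plausible range from 1000 nM to 9000 nM.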

Compound 4, half-maximal inhibitory concentration: 1780 nM
Compound 4: middle estimate off by 1.7-fold (0.23 log units), on the high side; the measured number falls inside the stated range.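

In this assay, putting (3-methoxyphenyl)amino in place of azetidin-1-yl on a double-bonded ring carbon gives an at least 8.9-fold lower number from compound 2 to compound 4 (0.95 log units; beyond the scatter), so this position can now be seen to respond clearly, whereas the floor of the earlier step stayed within the scatter. Compound 1 gives 2150 nM and compound 4 gives 1780 nM; these two values lie within the scatter of each other, so the 4-iodophenyl and 3-methoxyphenyl groups on the amine nitrogen show no order in this assay. The full size of the new step cannot be read, because compound 2 gives a limit and not a number: the limit of > 16000 nM in this assay, at which 1 of the 4 values shown sits.

The change replaces a four-membered non-aromatic ring with a six-membered aromatic ring and also brings in a hydrogen-bond donor, so the compounds shown cannot tell which of these parts goes with the lower number. On these data alone, an unsubstituted phenylamino group or a benzylamino group at this carbon would be the next comparison, and how either would read remains open.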